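The source may hold more compounds than are shown below. What is called first, only, known or untested is meant among the compounds shown, and "the series" means these compounds.

The measured compounds, in an ADME assay on Caco-2 cells (Homo sapiens) for permeability, in the apical to basolateral direction; a lower number here means that the compound crosses the layer more slowly, a higher number that the compound crosses the layer faster:
Compound 1, `CNC(=O)c1cc(Oc2ccc3nc(Nc4ccc(F)cc4)ncc3c2)ccn1`, gives < 1 10^-6 cm/s, a limit of the assay.
Compound 2, `CNC(=O)c1cc(Oc2ccc3nc(Nc4ccc(OC)cc4)ncc3c2)ccn1`, gives < 1 10^-6 cm/s, again a limit of the assay.

Compound 2 therefore stands at the floor of this assay, with no number of its own. For the measured compounds named here, the one measured step, a step that the two limits leave unreadable from compound 1 to compound 2, methoxy in place of fluoro on an aromatic carbon, cannot be read because the limit of < 1 10^-6 cm/s in this assay, at which 2 of the 2 values shown sit, covers both of its ends. Going by the values given here, nothing measured so far gives a size or a direction for any change on this core.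

Compound 3, `CNC(=O)c1cc(Oc2ccc3nc(Nc4ccc(Oc5ccccc5)cc4)ncc3c2)ccn1`, differs from compound 2 by phenyl in place of methyl on an oxygen on an aromatic ring. Among the compounds with values here, no measured step bears on this change, so no direction beyond the scatter can be drawn from the data. Compound 3 is expected to give about 0.8 10^-6 cm/s in this assay, within a range from 0.2 10^-6 cm/s to 3 10^-6 cm/s. The step from compound 2 to compound 3 is thus estimated as a step that the limit leaves unreadable from compound 2 to compound 3, with a fair chance that the assay again reports only a limit.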

Compound 3, apparent permeability: < 1 10^-6 cm/s
Compound 3: a limit, no number; the forecaster's own chance of this, stated with the estimate: 55%; the middle value is on the limit's open side.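

No step to compound 3 from compound 1 or compound 2 can be read in this assay, because all three compounds sit at one limit: the limit of < 1 10^-6 cm/s in this assay, at which 3 of the 3 values shown sit.

The compounds shown leave open how fast each crosses the layer, and whether fluoro, methoxy or phenoxy makes any difference on the shared core.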